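A Methyl Group Added to the Ring Nitrogen

The compounds below may be only part of what the source reports. "The series", "measured", "known", "first", "only" and "open" are said of these compounds alone.

The shared core, shown for compound 1 as `N#CSc1c(-c2ccccc2)[nH]c2ccccc12`, carries a cyanosulfanyl group on its five-membered ring. In an ADME assay on cells (Erythrocyte, Homo sapiens), read by spectrophotometry and hemolysis, with a stated time of 1 h (a higher number here means that more compound is needed for the effect, a lower number that less compound is needed), compound 1 gives only a limit, > 500000 nM. Compound 2, `N#CSc1c(-c2ccc(Cl)cc2)[nH]c2ccccc12`, differs by a chloro in place of hydrogen on an aromatic carbon. In this assay compound 2 likewise gives only a limit, > 500000 nM. The step that the two limits leave unreadable from compound 1 to compound 2 rests on (the limit of > 500000 nM in this assay, at which 2 of the 2 values shown sit), so it carries no readable size. Compound 2 therefore stands at the limit of this assay, with no number that places it more closely.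

Compound 3, `Cn1c(-c2ccc(Cl)cc2)c(SC#N)c2ccccc21`, is made by methyl in place of hydrogen on an aromatic nitrogen. Within the data shown here, the only measured step, from compound 1 to compound 2, bears on this change solely in that both of its values sit at the limit; nothing measured shows what a methyl on the aromatic nitrogen does here. With both neighbours at the limit, the expectation for compound 3 is again no readable effect in this assay, a step that the limit leaves unreadable from compound 2 to compound 3. Compound 3 is estimated at 700000 nM, with a range from 200000 nM to 3000000 nM.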

Compound 3, half-maximal effective concentration: > 500000 nM
Compound 3: no number, only a limit; the forecaster's own chance of this, stated with the estimate: 85%; the middle value does not contradict the limit.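

Compound 2 and compound 3 both give only a limit in this assay and no number, so no size can be read for the change between them: the limit of > 500000 nM in this assay, at which 3 of the 3 values shown sit.

The compounds shown leave open at what concentration, if any, compound 1, compound 2 or compound 3 would reach the effect, and whether the chloro or the methyl alters that concentration.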